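Dichlorophenyl for Acetylthiophene: Cytotoxicity Outlook

The source may report more compounds than this note shows. Statements on the series, on what has been measured and on what is new or still open speak of the compounds shown alone.

Two compounds of the series share a common core and have been tested for cytotoxicity. Compound 1 `CC(C)N(Cc1cccc(OCCCCCC(=O)O)c1)C(=O)c1ccc(-c2cccc3ccccc23)cc1` carries an acid chain, while compound 2 `CCOC(=O)CCCCCOc1cccc(CN(C(=O)c2ccc(-c3ccc(C(C)=O)s3)cc2)C(C)C)c1` carries the corresponding ethyl ester. In an ADME assay on HepG2 cells (Homo sapiens) for cytotoxicity, read by CellTiter-Glo and resazurin assay, with a stated time of 72 h (on this read-out lower numbers stand for an effect already at smaller amounts and higher numbers for an effect only at larger amounts of compound), compound 1 gives > 26000 nM, a limit of the assay rather than a number. Compound 2 gives > 26000 nM in this assay, which again is a limit and not a number. Compound 2 thus stands exactly where compound 1 stands, at the limit of > 26000 nM in this assay, at which 2 of the 2 values shown sit.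

Compound 3 `CCOC(=O)CCCCCOc1cccc(CN(C(=O)c2ccc(-c3ccc(Cl)c(Cl)c3)cc2)C(C)C)c1` has not yet been measured. It differs from compound 2 by 3,4-dichlorophenyl in place of 5-acetylthiophen-2-yl on an aromatic carbon. Within the data shown here, no measured step between compounds is available to guide the outlook. The step from compound 2 to compound 3 is expected to be a step that the limit leaves unreadable from compound 2 to compound 3, no change beyond the scatter. Compound 3 is therefore estimated at 30000 nM in this assay, within a range from 15000 nM to 60000 nM, most likely reported again as a limit.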

Compound 3, half-maximal effective concentration: > 26000 nM
Compound 3 gave a limit, no number (the forecaster's own chance of this, stated with the estimate: 75%); the middle value does not contradict the limit.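

Compound 2 and compound 3 both give a limit rather than a number in this assay, so no step between them can be read: the limit of > 26000 nM in this assay, at which 3 of the 3 values shown sit.

The compounds shown leave open at what concentration, if any, an effect appears, and whether 3,4-dichlorophenyl and 5-acetylthiophen-2-yl differ in it.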